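The compounds below may be only part of what the source reports. "The series", "measured", "known", "first", "only" and "open" are said of these compounds alone.

In an ADME assay on a cell-free system (plasma, Rattus norvegicus) for metabolic stability, read by LC-MS, with a stated time of 60 min, tested at 100 uM (a lower number here means that less of the compound is left, a higher number that more of the compound is left), compound 1 `Cc1cc(C(=O)O)ccc1OCCCCOc1ccc(C(=O)CC(C)C)c(O)c1C` gives 100% and compound 2 `Cc1ccc(C(=O)O)cc1OCCCCOc1ccc(C(=O)CC(C)C)c(O)c1C` gives 96% while compound 3 `COc1ccc(C(=O)O)cc1OCCCCOc1ccc(C(=O)CC(C)C)c(O)c1C` gives 99% on the same read-out. Compound 2 thus stands with the other two, within the scatter of each. Compound 4 `Cc1c(OCCCCOc2ccc(F)c(C(=O)O)c2)ccc(C(=O)CC(C)C)c1O` differs from compound 2 in one place, on an oxygen on a saturated carbon, with 3-carboxy-4-fluorophenyl in place of 5-carboxy-2-methylphenyl on an oxygen on a saturated carbon as the counted change: 3-carboxy-4-fluorophenyl in place of 5-carboxy-2-methylphenyl. For the measured compounds named here, two measured steps bear on this. Placing 5-carboxy-2-methylphenyl for 4-carboxy-2-methylphenyl gave a number 4 percentage points lower from compound 1 to compound 2 (within the scatter) and methoxy in place of methyl on an aromatic carbon gave a number 3 percentage points higher from compound 2 to compound 3 (within the scatter) and neither lies beyond the scatter. Going by the values given here, no measured compound carries fluorine, which leaves that part of the change untested. On these two small steps no shift beyond the scatter is expected in this assay for this change. The estimated step is a number 1 percentage points higher from compound 2 to compound 4 (within the scatter) and lies within the scatter. For compound 4 the expected value is 97% with an estimated range from 88% to 102% here.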

Compound 4, percent of the compound remaining: 101%
The estimate for compound 4 lay 4 percentage points below the measured number, within the range that was stated.
By their numbers in this assay, from the lowest: compounds 2, 3, 1 and 4 (each within the scatter of the next).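

In this assay, 3-carboxy-4-fluorophenyl on an oxygen on a saturated carbon gives a number 5 percentage points higher from compound 2 to compound 4 (within the scatter) against 5-carboxy-2-methylphenyl, and a number 1 percentage points higher from compound 1 to compound 4 (within the scatter) against 4-carboxy-2-methylphenyl. Fluorine, untested in the earlier compounds, therefore enters this place with no step beyond the scatter from either methyl-bearing comparator, and this holds with the carboxy group placed differently on the ring. No measurement on hand accounts for the read-out at this place.

From the compounds shown here alone, all four compounds carry a carboxylic acid on this ring, so the effect of an ester or an amide in its place remains open, as does that of a longer chain linking the two ether oxygens. Going by these compounds, whether either change would move the number in this assay beyond the scatter also remains open.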